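Methoxymethoxy in place of methoxy on the small core

This account rests on a few compounds, and the source may have more. Where it says the series, first, only, none or still open, it means among the compounds named here.

Of the compounds shown here, two have numbers so far. Compound 1 `COc1cc(OC)c(C(C)=O)c(OC)c1` gives 3800 nM in a functional assay on HeLa cells (Homo sapiens) for cytotoxicity, read by resazurin assay, with a stated time of 72 h (on this read-out higher numbers stand for weaker inhibition and lower numbers for stronger inhibition), and stands highest of the two. Compound 2 `COc1cc(OC)c(C(=O)/C=C/c2ccccc2)c(OC)c1Cc1ccccc1O`, which carries a longer side chain and a second aryl group, gives 2700 nM, and the gap between the two compounds is within the scatter, so the two numbers show no difference worth naming.

Compound 3 `COCOc1cc(OC)cc(OC)c1C(C)=O` has not been measured. It differs from compound 1 in one place: methoxy in place of hydrogen on a saturated chain carbon bound to an oxygen on an aromatic ring. Read one bond further out, methoxy becomes methoxymethoxy on the aromatic oxygen. Going by the values given here, no step between measured compounds that resembles this change is at hand, so no size can be read from the series itself; the expectation rests on the small scale of the change.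

The step from compound 1 to compound 3 is expected to be a 1.1-fold lower number from compound 1 to compound 3 (0.04 log units; within the scatter), none beyond the scatter. Compound 3 is therefore estimated at 3500 nM, with a range from 1500 nM to 9000 nM.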

Compound 3, half-maximal inhibitory concentration: 14000 nM
Beside the measured number, compound 3's estimate is 4.0-fold (0.60 log units) below it; measured number outside the range, above it.
By their numbers in this assay, from the lowest: compounds 2 and 1 (each within the scatter of the next); then compound 3.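

Methoxymethoxy in place of methoxy on the core of compound 1 gives a 3.7-fold higher number from compound 1 to compound 3 (0.57 log units; beyond the scatter) in this assay, the only step in the series read so far and one that lies beyond the scatter. The aromatic oxygen of this small core is therefore a position where this modest extension of the methoxy group weakens inhibition in this read-out, though the size of the step is modest. No measurement at hand bears on the reason for this step.

The compounds shown leave open whether a hydroxyl, an ethoxy group or a longer chain on this oxygen would shift the number in the same way. They also leave open whether methoxymethoxy gives a step of similar size on the core of compound 2, with its longer side chain and second aryl group.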